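This account rests on a few compounds, and the source may have more. Where it says the series, first, only, none or still open, it means among the compounds named here.

Compound 1 `CCN(C)Cc1c(OC)cc(OC)c(C(=O)/C=C/c2ccccc2Cl)c1O` is the stronger of the two compounds measured here. In a functional assay on HL-60 cells (Homo sapiens) for antiproliferative activity, with a stated time of 72 h (a higher number here means a weaker inhibitor, a lower number a stronger inhibitor), compound 1 gives 200 nM. Compound 2 `COc1cc(OC)c2c(=O)cc(-c3ccccc3Cl)oc2c1CN1CCCCC1`, which has a different core, gives 34500 nM in this assay, a much higher number than compound 1, and the gap between the two lies well beyond the scatter of repeated runs.

Compound 3 `COc1cc(OC)c(C(=O)/C=C/c2ccccc2Cl)c(O)c1CN(C)CCCN(C)C` has not yet been measured. Compared with compound 1 it carries (dimethylamino)methyl in place of hydrogen on a saturated chain carbon, two bonds along the chain from an amine nitrogen. For the measured compounds named here, no pair of measured compounds here differs by a single change of this kind, so there is no measured step to lean on. The shared core of compound 1 and the chain it bears are kept, and the change adds to the chain rather than altering the core. On that basis the step is expected to be small, within the scatter, with no clear direction. Compound 3 is therefore estimated at 250 nM, with a range of 80 nM to 800 nM, and the expected step is a 1.3-fold higher number from compound 1 to compound 3 (0.10 log units; within the scatter).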

Compound 3, half-maximal inhibitory concentration: 11400 nM
The estimate for compound 3 lay 46-fold (1.66 log units) below the measured number, and the stated range ends below it.
By their numbers in this assay, from the lowest: compound 1; then compound 3; then compound 2.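

In this assay, changing ethyl to 3-(dimethylamino)propyl on the amine nitrogen gives a 57-fold higher number from compound 1 to compound 3 (1.76 log units; beyond the scatter), a large weakening with the rest of the molecule unchanged. The two earlier compounds differ in their core and could say nothing about this chain, whereas this pair shows that activity is sensitive to what the amine nitrogen carries, and that an addition here is not a neutral change. Nothing measured here explains the loss.

The compounds shown leave open whether the weakening follows the longer chain or the added dimethylamino group, a question that a plain butyl chain or a 3-hydroxypropyl chain in the same place could help to separate. A shorter 2-(dimethylamino)ethyl chain would show whether the loss changes with chain length.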